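Cyclopropylidene purines: cytotoxicity notes toward compound 4

The source may report more compounds than this note shows. Statements on the series, on what has been measured and on what is new or still open speak of the compounds shown alone.

compound 1 `CCOc1nc(N)nc2c1ncn2/C=C1/CC1(CO)CO` – a limit in an ADME assay on HFF cells (Homo sapiens) for cytotoxicity, with a stated time of 8 days; on this read-out higher numbers stand for lower toxicity in this test and lower numbers for higher toxicity in this test: > 300000 nM
compound 2 `COCCOc1nc(N)nc2c1ncn2/C=C1/CC1(CO)CO` – a limit in this assay: > 300000 nM
compound 3 `CCCNc1nc(N)nc2c1ncn2/C=C1/CC1(CO)CO` – a limit in this assay: > 300000 nM

Going by the values given here, compound 3 stands at the same limit as the other two; the limit of > 300000 nM in this assay, at which 3 of the 3 values shown sit, marks the position shared by all values so far. The three steps among the measured compounds are a step that the two limits leave unreadable from compound 1 to compound 2, a step that the two limits leave unreadable from compound 1 to compound 3 and a step that the two limits leave unreadable from compound 2 to compound 3: none is readable, so none gives a size to carry forward. Compound 4 `CCCCSc1nc(N)nc2c1ncn2/C=C1/CC1(CO)CO` differs from compound 3 by butylsulfanyl in place of propylamino on an aromatic carbon. With every measured compound sitting at the limit, no readable step bears on this change. Compound 4 is expected to give 300000 nM, with the estimate ranging from 100000 nM to 1000000 nM. The expected step is a number no higher from compound 3 to compound 4 (the limit leaves the size open), most likely again reported as a limit rather than a number.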

Compound 4, half-maximal cytotoxic concentration: > 300000 nM
Compound 4 was reported as a limit; the forecaster's own chance of this, stated with the estimate: 85%; the middle value sits exactly at the limit.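

Going by these compounds alone, no step from compound 1, compound 2 or compound 3 to compound 4 can be read, as all four sit at one limit: the limit of > 300000 nM in this assay, at which 4 of the 4 values shown sit.

The compounds shown leave open whether, in this assay, any group on this aromatic carbon changes the cytotoxicity.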